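Chain length and a hydroxamic acid on a shared core

The source may report more compounds than this note shows. Statements on the series, on what has been measured and on what is new or still open speak of the compounds shown alone.

Compound 1 `Nc1ncnc2c1c(-c1cnc3[nH]ccc3c1)nn2CC(=O)NO`: > 150000 nM
Compound 2 `Nc1ncnc2c1c(-c1cnc3[nH]ccc3c1)nn2CCCCC(=O)NO`: > 150000 nM
Compound 3 `Nc1ncnc2c1c(-c1cnc3[nH]ccc3c1)nn2CCCCCCCCCC(=O)NO`: 6550 nM

In a functional assay on A549 cells (Homo sapiens) for inhibition, read by MTT assay, with a stated time of 72 h (a higher number here means a weaker inhibitor, a lower number a stronger inhibitor), compound 1 gives > 150000 nM, which is a limit of the assay and not a number. In this assay compound 2 likewise gives > 150000 nM, again a limit. Among the compounds with values here, compound 3 gives 6550 nM in this assay, the only number among the three. Compound 3 differs from compound 2 by 5-(hydroxycarbamoyl)pentyl in place of hydroxycarbamoyl on a saturated chain carbon, four bonds along the chain from an aromatic nitrogen, and the step is an at least 22-fold lower number from compound 2 to compound 3 (1.35 log units; beyond the scatter). Compound 1 differs from compound 2 by hydroxycarbamoyl in place of 3-(hydroxycarbamoyl)propyl on a saturated chain carbon bound to an aromatic nitrogen, a step that is a step that the two limits leave unreadable from compound 2 to compound 1 because both sit at the limit of > 150000 nM in this assay, at which 2 of the 3 values shown sit.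

Compound 4 `Nc1ncnc2c1c(-c1cnc3[nH]ccc3c1)nn2CCCCCCC(=O)NO` is not yet measured. Within the data shown here, it differs from compound 3 by hydroxycarbamoyl in place of 3-(hydroxycarbamoyl)propyl on a saturated chain carbon, six bonds along the chain from an aromatic nitrogen, the same kind of change as the one from compound 2 to compound 1, but at a different place along the chain. That earlier step cannot be read. Shortening the chain moved compound 2 to a limit relative to compound 3, so compound 4 is expected to sit between them with a step of a 6.1-fold higher number from compound 3 to compound 4 (0.79 log units; beyond the scatter). The estimate for compound 4 is 40000 nM, between 10000 nM and 150000 nM.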

Compound 4, half-maximal inhibitory concentration: 50000 nM
Estimate against measurement, compound 4: 1.3-fold (0.10 log units) below; the measured number falls inside the stated range.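

In this assay, replacing 3-(hydroxycarbamoyl)propyl with hydroxycarbamoyl at the far end of the longest chain gives a 7.6-fold higher number from compound 3 to compound 4 (0.88 log units; beyond the scatter), while extending the shorter chains gives an at least 3.0-fold lower number from compound 2 to compound 4 (0.47 log units; beyond the scatter) and an at least 3.0-fold lower number from compound 1 to compound 4 (0.47 log units; beyond the scatter), so compound 4 holds a readable place on the chain series. Carried from one core to another, the lengthening of the chain by the same difference runs in the same direction, but its size cannot be compared: the same change on two cores in this assay, an at least 22-fold lower number (1.35 log units; beyond the scatter) from compound 2 to compound 3 and an at least 3.0-fold lower number (0.47 log units; beyond the scatter) from compound 1 to compound 4; the limit leaves it open whether they differ Compound 1 and compound 2 each rest on a limit and not on a number, so the step between them cannot be read and any step from them gives only a bound: the limit of > 150000 nM in this assay, at which 2 of the 4 values shown sit.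

The compounds shown leave open whether a longer chain than that of compound 3 would lower the number further. They also leave open whether a carboxylic acid at the chain end, in place of the hydroxamic acid, would read the same.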